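The source may report more compounds than this note shows. Statements on the series, on what has been measured and on what is new or still open speak of the compounds shown alone.

Compound 1, `O=C1[C@H](CCc2ccccc2)N(Cc2ccc(-c3ccccc3-c3nn[nH]n3)cc2F)C(=O)N1CCCN1CCCCC1`: 1600 nM
Compound 2, `O=C1[C@H](Cc2c[nH]c3ccccc23)N(Cc2ccc(-c3ccccc3-c3nn[nH]n3)cc2)C(=O)N1C1CCNCC1`: 50000 nM

Within the data shown here, in an in vitro assay on BHK cells for binding affinity to growth hormone secretagogue receptor type 1 (Homo sapiens) (on this read-out higher numbers stand for weaker inhibition and lower numbers for stronger inhibition), compound 1 gives 1600 nM, the lower of the two numbers measured so far. Compound 2 gives 50000 nM in this assay, a much higher number whose gap to compound 1 lies beyond the scatter; the two structures differ in several places at once, so that gap says nothing about any single change.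

The next compound, compound 3, `O=C1[C@H](CCc2ccccc2)N(Cc2ccc(-c3ccccc3-c3nn[nH]n3)cc2)C(=O)N1CCCN1CCCCC1`, differs from compound 1 in one place only: hydrogen in place of fluoro on an aromatic carbon. Among the measured compounds shown here, no pair of measured compounds shows this change on its own, so the expectation rests on the value of compound 1 alone. A small step is expected, in no definite direction, and most likely within the usual scatter. For compound 3 the expected value in this assay is 2000 nM, with a range from 700 nM to 6000 nM. That estimate means an expected step of a 1.3-fold higher number from compound 1 to compound 3 (0.10 log units; within the scatter).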

Compound 3, half-maximal inhibitory concentration: 600 nM
The estimate for compound 3 lay 3.3-fold (0.52 log units) above the measured number; the whole stated range lies above it.
By their numbers in this assay, from the lowest: compound 3; then compound 1; then compound 2.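

In this assay, among these compounds, the swap of fluoro for hydrogen gives a 2.7-fold lower number from compound 1 to compound 3 (0.43 log units; beyond the scatter) and this is the first change that can be read on its own. It shows that this aromatic carbon, ortho to a large group, is not indifferent to what it carries, and that the fluoro is not needed for the lower number in this pair, where the rest of the structure stays the same. Nothing given here accounts for the step.

From the compounds shown here alone, whether chlorine, methyl or methoxy on this same carbon would lower or raise the number remains open. Going by these compounds, it is also open whether the fluoro would give a step of similar size and direction on a compound with different side chains on the shared core, since this single pair cannot show it.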